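The compounds below may be only part of what the source reports. "The series", "measured", "known", "first", "only" and "open" are said of these compounds alone.

The measured compounds:
Compound 1 `O=Cc1ccc(-c2cn3ccnc3c(-c3ccc4ncn(C5CCCCC5)c4c3)n2)cc1` gives 92.6% in a functional assay on HCT-116 cells (Homo sapiens) for inhibition, read by sulforhodamine B assay, with a stated time of 48 h, tested at 10 uM; a higher number here means more inhibition at the concentration tested (going by the name of the read-out), a lower number less inhibition.
Compound 2 `c1ccc2c(-c3cn4ccnc4c(-c4ccc5ncn(C6CCCCC6)c5c4)n3)cccc2c1` gives 17.9% in this assay.
Compound 3 `c1cn2cc(-c3ccsc3)nc(-c3ccc4ncn(C5CCCCC5)c4c3)c2n1` gives 13.4% in this assay.

Compound 1 stands highest of the three numbers, and both steps away from it are large: a number 74.7 percentage points lower from compound 1 to compound 2 (beyond the scatter) and a number 79.2 percentage points lower from compound 1 to compound 3 (beyond the scatter). Between compound 2 and compound 3 the step stays within the scatter: a number 4.5 percentage points lower from compound 2 to compound 3 (within the scatter).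

Compound 4 `O=Cc1ccc(-c2cn3ccnc3c(-c3ccc4ncn(Cc5ccccc5)c4c3)n2)cc1` differs from compound 1 in a different place than the measured steps do: benzyl in place of cyclohexyl on an aromatic nitrogen. Among the compounds with values here, all three measured steps change the group on the aromatic carbon, and none touches the group on the ring nitrogen, so no measured step bears on this change. What the data do show is that the group on the aromatic carbon as it stands in compound 1, which compound 4 keeps, goes with high inhibition. Without a direct guide, the expectation for compound 4 is a modest loss, a number 22.6 percentage points lower from compound 1 to compound 4 (beyond the scatter), with a wide range. Compound 4 is therefore estimated at 70%, between 25% and 95%.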

Compound 4, a percentage reported as inhibition, at one concentration (the size of the read-out at that concentration, not a potency): 92.6%
The estimate for compound 4 lay 22.6 percentage points below the measured number; measured number inside the range.
By their numbers in this assay, from the lowest: compounds 3 and 2 (each within the scatter of the next); then compounds 1 and 4 (each within the scatter of the next).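

In this assay, within the data shown here, the first change at the ring nitrogen, benzyl in place of cyclohexyl, gives no change at the digits printed from compound 1 to compound 4 (within the scatter), whereas the earlier changes on the aromatic carbon moved the number by far more. With 4-formylphenyl kept on the aromatic carbon, this nitrogen can therefore carry either the non-aromatic ring of cyclohexyl or the aromatic ring of benzyl without any separation in this read-out. No measurement offered here explains why the two groups match.

Going by these compounds, it remains open whether a 2-aminoethyl chain or a group bearing a carboxylic acid on this nitrogen would also keep the number, and whether benzyl would match cyclohexyl with naphthalen-1-yl or thiophen-3-yl on the aromatic carbon. A reading at one concentration also leaves open whether compound 1 and compound 4 differ in potency.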